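The source may report more compounds than this note shows. Statements on the series, on what has been measured and on what is new or still open speak of the compounds shown alone.

Measured so far in a functional assay (Prostate gland) for cytotoxicity, with Homo sapiens as the target; on this read-out higher numbers stand for weaker inhibition of growth and lower numbers for stronger inhibition of growth:
- Compound 1 `CCCCCCn1c(=O)oc2ccc(NCc3cc(O)ccc3O)cc2c1=O`: 13800 nM
- Compound 2 `Oc1ccc(O)c(CNc2ccc(O)c(/C=C\CCc3ccccc3)c2)c1`: 34000 nM

Of these two, compound 2 has the higher number, so it inhibits growth more weakly, and its gap to compound 1 lies beyond the usual scatter.

Compound 3 `Oc1ccc(O)c(CNc2ccc(O)c(/C=C/CCc3ccccc3)c2)c1` has the same atoms and bonds as compound 2: the two compounds have the same atoms and bonds and differ only in configuration as drawn: 1 of 1 stereo elements differ; a double bond is drawn Z in compound 2 and E in compound 3. A double bond drawn Z in compound 2 is drawn E in compound 3.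

For the measured compounds named here, no measured pair shows what such a switch does, so no change beyond the scatter is expected in this assay. The expected step is a 1.1-fold lower number from compound 2 to compound 3 (0.05 log units; within the scatter). For compound 3 the estimated value is 30000 nM, with an expected range from 12000 nM to 70000 nM.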

Compound 3, concentration for 50% growth inhibition: 18700 nM
Estimate against measurement, compound 3: 1.6-fold (0.21 log units) above; low and high end bracket the measured number.
By their numbers in this assay, from the lowest: compounds 1, 3 and 2 (each within the scatter of the next, the first and the last beyond it).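

Going from the Z to the E double bond gives a 1.8-fold lower number from compound 2 to compound 3 (0.26 log units; within the scatter) in this assay. For the compounds shown here, this is the first direct read on this double bond, and its geometry does not separate the two compounds in growth inhibition. Nothing else in the structure can account for any gap, since the comparison is clean: the fact that compounds 2 and 3 differ only in the configuration as drawn

Going by these compounds, it remains open whether a saturated chain in place of this double bond, or a longer chain, would shift the number. On these data alone, it is also open whether the same switch would stay this small in a molecule carrying a carboxylic acid.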